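An Aryl Swap on the Ring Amine Nitrogen

The source may hold more compounds than are shown below. What is called first, only, known or untested is meant among the compounds shown, and "the series" means these compounds.

Three compounds have been measured in an assay on a cell-free system (plasma) for inhibition of Dipeptidyl peptidase 4 (Rattus norvegicus), read by fluorescence; on this read-out lower numbers stand for stronger inhibition and higher numbers for weaker inhibition:
compound 1 `CN1CCN([C@@H]2CN[C@H](C(=O)N3CCSC3)C2)CC1` gives 81.1 nM
compound 2 `COc1ccc(N2CCN([C@@H]3CN[C@H](C(=O)N4CCSC4)C3)CC2)cc1` gives 16.9 nM
compound 3 `O=C([C@@H]1C[C@H](N2CCN(c3ccc(Cl)cc3)CC2)CN1)N1CCSC1` gives 10.3 nM

Compound 3 stands at the lowest number of the three in this assay. Its separation from compound 1 is clear, a 7.9-fold lower number from compound 1 to compound 3 (0.90 log units; beyond the scatter), while its separation from compound 2 is not, a 1.6-fold lower number from compound 2 to compound 3 (0.22 log units; within the scatter), so compounds 2 and 3 cannot be ranked against each other.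

Compound 4 `N#Cc1cccnc1N1CCN([C@@H]2CN[C@H](C(=O)N3CCSC3)C2)CC1` has not yet been measured. It differs from compound 3 in one place: 3-cyanopyridin-2-yl in place of 4-chlorophenyl on an amine nitrogen in a ring.

Within the data shown here, no measured step exchanges one aromatic ring for another on this nitrogen. Two steps show that an aromatic ring in place of methyl on this ring nitrogen lowers the number modestly, a 4.8-fold lower number from compound 1 to compound 2 (0.68 log units; beyond the scatter) and a 7.9-fold lower number from compound 1 to compound 3 (0.90 log units; beyond the scatter). Among the measured compounds shown here, the one step that alters only the aromatic ring itself stays within the scatter, a 1.6-fold lower number from compound 2 to compound 3 (0.22 log units; within the scatter). Compound 4 keeps an aromatic ring on the same nitrogen, so the expected step is small, a 1.3-fold lower number from compound 3 to compound 4 (0.11 log units; within the scatter), with no direction that can be trusted beyond the scatter. For compound 4 the estimate in this assay is therefore 8 nM, within a range of 2.5 nM to 25 nM.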

Compound 4, half-maximal inhibitory concentration: 1.2 nM
Estimate against measurement, compound 4: 6.7-fold (0.82 log units) above, outside the stated range (below it).
By their numbers in this assay, from the lowest: compound 4; then compounds 3 and 2 (each within the scatter of the next); then compound 1.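

In this assay, the aromatic ring on this amine nitrogen turns out not to be interchangeable: 3-cyanopyridin-2-yl in place of 4-chlorophenyl gives an 8.6-fold lower number from compound 3 to compound 4 (0.93 log units; beyond the scatter) and in place of 4-methoxyphenyl gives a 14-fold lower number from compound 2 to compound 4 (1.15 log units; beyond the scatter), whereas chloro in place of methoxy stayed within the scatter (a 1.6-fold lower number from compound 2 to compound 3 (0.22 log units; within the scatter)). The position therefore responds to the identity of the aromatic ring and not merely to its presence, and the step from methyl widens to a 68-fold lower number from compound 1 to compound 4 (1.83 log units; beyond the scatter), well past the steps from methyl to either of the other two aromatic groups. Nothing available here accounts for this difference.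

The change brings in a ring nitrogen and a nitrile together, so the compounds shown leave open which of the two carries the step, or whether both are needed. A plain pyridin-2-yl without the nitrile and a phenyl ring bearing a nitrile would separate the two contributions on this same nitrogen.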